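A Second Methoxy on the Aryl Arm of Compound 3

The source may report more compounds than this note shows. Statements on the series, on what has been measured and on what is new or still open speak of the compounds shown alone.

Compound 1: `COc1ccc(-c2cc(C(=O)Nc3nc4ccc(F)cc4s3)nc3cc(-c4ccccc4)nn23)cc1OC` gives 8310 nM
Compound 2: `COc1ccc2nc(NC(=O)c3cc(-c4ccc(F)cc4)n4nc(-c5ccccc5)cc4n3)sc2c1` gives 17300 nM
Compound 3: `COc1ccc(-c2cc(C(=O)Nc3nc4ccc(OC)cc4s3)nc3cc(-c4ccccc4)nn23)cc1` gives 24500 nM
Compound 4: `COc1ccc2nc(NC(=O)c3cc(-c4ccc(OC)c(OC)c4)n4nc(-c5ccccc5)cc4n3)sc2c1` not yet measured

All three measured compounds were tested in a functional assay on HeLa cells (Homo sapiens) for cytotoxicity, read by MTT assay, with a stated time of 48 h; on this read-out higher numbers stand for weaker inhibition and lower numbers for stronger inhibition. Compound 3 has the highest of the three numbers; its nearest neighbour is compound 2, and the step of a 1.4-fold higher number from compound 2 to compound 3 (0.15 log units; within the scatter) lies within the scatter. Its furthest neighbour is compound 1, whose number is lower by a margin beyond the scatter, but the two compounds differ in two places, so no single step can be read from that pair.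

Compound 4 differs from compound 3 by methoxy in place of hydrogen on an aromatic carbon. Among the compounds with values here, no measured step isolates this change. Compound 1 carries the same 3,4-dimethoxyphenyl and shows the lowest number, yet it also carries fluoro rather than methoxy on the other ring, so the comparison is confounded. Within the data shown here, the one clean step, a 1.4-fold higher number from compound 2 to compound 3 (0.15 log units; within the scatter), concerns a different position and was flat.

Compound 4 is therefore expected to show a modest step, a 1.8-fold lower number from compound 3 to compound 4 (0.24 log units; within the scatter), toward a lower number, with wide uncertainty. The estimate for compound 4 is 14000 nM, expected within 5000 nM to 40000 nM.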

Compound 4, half-maximal inhibitory concentration: 11000 nM
Beside the measured number, compound 4's estimate is 1.3-fold (0.10 log units) above it; measured number inside the range.
By their numbers in this assay, from the lowest: compounds 1, 4, 2 and 3 (each within the scatter of the next, the first and the last beyond it).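

In this assay, within the data shown here, the second methoxy gives the first isolated reading of this aromatic carbon, a modest step beyond the scatter: a 2.2-fold lower number from compound 3 to compound 4 (0.35 log units; beyond the scatter). The whole arm exchange of 3,4-dimethoxyphenyl for 4-fluorophenyl stays flat, with a 1.6-fold lower number from compound 2 to compound 4 (0.20 log units; within the scatter), so this assay does not separate those two arms. The methoxy-for-fluoro exchange can now be read a second time, giving a 1.3-fold higher number from compound 1 to compound 4 (0.12 log units; within the scatter), and it proves as flat as on the earlier pair: the same change on two cores in this assay, a 1.4-fold higher number (0.15 log units; within the scatter) from compound 2 to compound 3 and a 1.3-fold higher number (0.12 log units; within the scatter) from compound 1 to compound 4, 1.1-fold (0.03 log units) apart, within the scatter of two such steps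

On these data alone, it remains open whether the step at this carbon is specific to methoxy, which a hydroxyl, an amine or a longer ethoxy chain in the same place would test. As far as these compounds go, it is also open whether the step from 4-methoxyphenyl to 3,4-dimethoxyphenyl holds with fluoro on the other ring.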